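Series notes: furan-2-yl in place of 4-fluorophenyl

The compounds below may be only part of what the source reports. "The series", "measured", "known", "first", "only" and "open" are said of these compounds alone.

The series shares the core of compound 1 `CC1=CC[C@H](C(C)(C)NC(=S)NN)CC1`, which in a functional assay on U-251 cells (Homo sapiens) for inhibition, read by sulforhodamine B assay, with a stated time of 48 h (on this read-out lower numbers stand for stronger inhibition of growth and higher numbers for weaker inhibition of growth), gives 200 nM. Compound 2 `CC1=CC[C@H](C(C)(C)NC(=S)N/N=C/c2ccccc2)CC1` carries a benzylidene hydrazone and in this assay gives 26300 nM. Compound 3 `CC1=CC[C@H](C(C)(C)NC(=S)N/N=C/c2ccc(F)cc2)CC1` is reported in this assay only as a limit, > 100000 nM. The step of an at least 3.8-fold higher number from compound 2 to compound 3 (0.58 log units; beyond the scatter) therefore rests on (the limit of > 100000 nM in this assay, at which 1 of the 3 values shown sits). Compound 4 `CC1=CC[C@H](C(C)(C)NC(=S)N/N=C/c2ccco2)CC1` differs from compound 3 by furan-2-yl in place of 4-fluorophenyl on a carbon with a double bond to nitrogen. Within the data shown here, only the step from compound 2 to compound 3 bears on this change, and it concerns a fluoro, not a ring swap, so it fixes no direction. Both compounds 2 and 3 give far higher numbers than compound 1. Compound 4 is expected to remain in that weak region, with an at least 2.0-fold lower number from compound 3 to compound 4 (0.30 log units; that floor lies within the scatter) estimated. Compound 4 is estimated at 50000 nM, between 10000 nM and 200000 nM.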

Compound 4, concentration for 50% growth inhibition: 9700 nM
Compound 4: middle estimate off by 5.2-fold (0.71 log units), on the high side; the measured number lies below the stated range.
By their numbers in this assay, from the lowest: compound 1; then compound 4; then compound 2. At a limit, above all of these: compound 3.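

In this assay, the ring on the carbon with a double bond to nitrogen can be changed with a clear result: furan-2-yl gives an at least 10-fold lower number from compound 3 to compound 4 (1.01 log units; beyond the scatter), and in place of phenyl it gives a 2.7-fold lower number from compound 2 to compound 4 (0.43 log units; beyond the scatter). Compound 3 stands at a limit and not at a number: the limit of > 100000 nM in this assay, at which 1 of the 4 values shown sits. Furan-2-yl still does not restore the level of the shared core, with a 49-fold higher number from compound 1 to compound 4 (1.69 log units; beyond the scatter).

Going by these compounds, it remains open whether thiophen-2-yl, with sulfur in place of the furan oxygen, would follow furan-2-yl. On these data alone, it also remains open whether an amine on the ring would bring the number closer to that of compound 1.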